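Compound 4 in the solubility series

A few compounds are considered here, and "the series" means these few. Any claim that something is new, unique, unknown or untested is made for them only; others in the source may bear on it.

- compound 1 `CCn1ncc2c(F)cc(-c3ccc(C(CC)(CC)c4nnc[nH]4)c(=O)[nH]3)cc21` gives 35500 nM
- compound 2 `CCC(CC)(c1nnc[nH]1)c1ccc(-c2ccc3cccc(F)c3c2)[nH]c1=O` gives 31200 nM
- compound 3 `CC(C)C(Cc1noc(=O)[nH]1)c1ccc(-c2ccc3cccc(F)c3c2)[nH]c1=O` gives 30400 nM

All three numbers come from a physicochemical assay for solubility, in phosphate buffer, measured as kinetic solubility (a lower number here means a less soluble compound, a higher number a more soluble compound), and lie within the scatter of one another. Compound 3 therefore stands level with compound 1 and compound 2 on these data, and no order can be read among them. Going by the values given here, no two of the three differ in one place only, so no measured step is available as a guide.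

Compound 4 `CC(C)C(/C=C1\CCNC1=O)c1ccc(-c2ccc3cccc(F)c3c2)[nH]c1=O` has not yet been measured. Its change from compound 3 is a group of 7 heavy atoms (5 carbon, 1 nitrogen, 1 oxygen; one five-membered non-aromatic ring with 1 hetero atom) in place of a group of 7 heavy atoms (3 carbon, 2 nitrogen, 2 oxygen; one five-membered aromatic ring with 3 hetero atoms), on a saturated chain carbon bound to an aromatic carbon and a saturated chain carbon and the rest of the structure stays the same. A group with one five-membered aromatic ring with 3 hetero atoms thus gives way to one with a five-membered non-aromatic ring with 1 hetero atom.

The three measured numbers offer no direct reading on the entering group, so the expectation in this assay is cautious: a modest move toward a lower number, possibly none beyond the scatter. It starts from compound 3 at 30400 nM as its anchor. The estimated step is a 1.5-fold lower number from compound 3 to compound 4 (0.18 log units; within the scatter) and remains only an expectation. For compound 4 the estimate is 20000 nM with an expected range from 7000 nM to 40000 nM for the coming measurement.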

Compound 4, solubility: 20700 nM
Estimate against measurement, compound 4: 1.0-fold (0.01 log units) below; the measured number falls inside the stated range.
By their numbers in this assay, from the lowest: compounds 4, 3, 2 and 1 (each within the scatter of the next).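

Going by these compounds alone, this is the first step that can be read at one place. On a saturated chain carbon bound to an aromatic carbon and a saturated chain carbon, a five-membered non-aromatic ring with 1 hetero atom takes the place of a five-membered aromatic ring with 3 hetero atoms, and in this assay the result is a 1.5-fold lower number from compound 3 to compound 4 (0.17 log units; within the scatter). At this position, then, the exchange of the aromatic ring for the non-aromatic one, with 1 hydrogen-bond acceptor entering where 3 hydrogen-bond acceptors leave and 1 hydrogen-bond donor on each side, does not carry the number beyond the scatter, and neither group stands apart from the other on this read-out. No measurement at hand bears on the origin of this step.

The compounds shown leave open whether any group on this carbon, such as a carboxylic acid or an amine, would give a step beyond the scatter. They also leave open whether the same exchange would read alike on a different core, such as that of compound 1.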